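Phenyl for furan-3-yl at the limit of the assay

The source may report more compounds than this note shows. Statements on the series, on what has been measured and on what is new or still open speak of the compounds shown alone.

Compound 2 `COc1nc(N)nc2c1c(-c1ccoc1)cn2[C@@H]1O[C@H](CO)[C@@H](O)[C@H]1O` reads > 100000 nM in an ADME assay on MRC5 cells (Homo sapiens), read by MTT assay, with a stated time of 72 h (a higher number here means a weaker inhibitor, a lower number a stronger inhibitor), as a limit of the assay and not a number. Compound 1 `CN(C)c1ncnc2c1c(-c1ccsc1)cn2[C@@H]1O[C@H](CO)[C@@H](O)[C@H]1O` also reads > 100000 nM in this assay as a limit. Both known results therefore stand at the same place, the limit of > 100000 nM in this assay, at which 2 of the 2 values shown sit, and neither can be ranked against the other.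

Compound 3 `COc1nc(N)nc2c1c(-c1ccccc1)cn2[C@@H]1O[C@H](CO)[C@@H](O)[C@H]1O` keeps the core of compound 2 and carries phenyl in place of furan-3-yl on an aromatic carbon in that one position. Among the compounds with values here, no measured pair shows what such a swap does. Compound 2 reads > 100000 nM as a limit and offers no number to step from, so no change beyond the usual scatter is expected. The expected change a number no higher from compound 2 to compound 3 (the limit leaves the size open) is estimated to stay within that scatter. For compound 3 the estimate is 100000 nM with an expected range from 30000 nM to 200000 nM in this assay.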

Compound 3, half-maximal inhibitory concentration: > 100000 nM
Compound 3: only a limit was reported (the forecaster's own chance of this, stated with the estimate: 75%); the middle value lies on the limit itself.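

No step from compound 2 to compound 3 can be read in this assay, because both results are limits of the assay and not numbers: the limit of > 100000 nM in this assay, at which 3 of the 3 values shown sit.

The compounds shown leave open whether phenyl and furan-3-yl differ at all here, and how the three compounds rank against one another.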